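This account rests on a few compounds, and the source may have more. Where it says the series, first, only, none or still open, it means among the compounds named here.

Series notes. In a functional assay on A2780 cells (Homo sapiens) for inhibition, read by sulforhodamine B assay, with a stated time of 72 h (a higher number here means a weaker inhibitor, a lower number a stronger inhibitor), compound 1 `O=C(NCc1ccc(S(=O)(=O)c2ccccc2C(F)(F)F)cc1)c1cc2cnccc2[nH]1` gives 25 nM, the higher of the two numbers recorded, while compound 3 `O=C(NCc1ccc(S(=O)(=O)c2cccc(C(F)(F)F)c2)cc1)c1ccc2nccn2c1` gives 2 nM, a lower figure that lies beyond the scatter. Compound 2 `O=C(NCc1ccc(S(=O)(=O)c2ccccc2)cc1)c1cc(-c2cccnc2)no1` returns only a limit, > 10000 nM, and nothing more is known of it than that limit (the limit of > 10000 nM in this assay, at which 1 of the 3 values shown sits). Compound 4 `Cc1ccccc1S(=O)(=O)c1ccc(CNC(=O)c2cc3cnccc3[nH]2)cc1` is not yet measured; it differs from compound 1 in one place, (methyl in place of trifluoromethyl on an aromatic carbon). Among the compounds with values here, no measured pair in the set carries this change, so no step size is known for it. The expected step of a 1.6-fold higher number from compound 1 to compound 4 (0.20 log units; within the scatter) is small, within the usual scatter, with a slight lean toward a higher number. Compound 4 is therefore estimated at 40 nM, in the range 10 nM to 160 nM.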

Compound 4, half-maximal inhibitory concentration: 13 nM
For compound 4 the middle estimate is 3.1-fold (0.49 log units) above the measured one; low and high end bracket the measured number.
By their numbers in this assay, from the lowest: compound 3; then compounds 4 and 1 (each within the scatter of the next). At a limit, above all of these: compound 2.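

In this assay, within the data shown here, 2-methylphenyl in place of 2-(trifluoromethyl)phenyl gives a 1.9-fold lower number from compound 1 to compound 4 (0.28 log units; within the scatter) and is the first step read at this position. On the core of compound 1, the fluorine atoms can therefore leave this aromatic carbon with no change distinguishable from the scatter. No measurement shown bears on the cause of this step.

As far as these compounds go, whether a methoxy group, a chlorine atom or an ethyl group at this place would behave like methyl remains open. So does whether methyl in place of trifluoromethyl reads the same on the core of compound 3.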